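A Methyl on Selenium: Compound 4 Expected to Stay Inert

The source may hold more compounds than are shown below. What is called first, only, known or untested is meant among the compounds shown, and "the series" means these compounds.

Three close relatives of the shared core have been run through a functional assay on CCRF-CEM cells (Homo sapiens) for cytotoxicity, read by MTT assay, with a stated time of 72 h; a lower number here means that less compound is tolerated, a higher number that more compound is tolerated. Compound 1 `COc1ccc(CNc2nc([Se]C)nc3ccccc23)cc1` reaches only a limit of the measurement there, > 100000 nM, not a number. Compound 2 `CCCCC[Se]c1nc(NCc2ccccc2)c2ccccc2n1` likewise gives only a limit, > 100000 nM. Compound 3 `[SeH]c1nc(NCc2ccccc2)c2ccccc2n1`, carrying a bare hydrogen on the selenium, also gives only a limit, > 100000 nM. Within the data shown here, the one single-change step between measured compounds, a step that the two limits leave unreadable from compound 2 to compound 3, is therefore unreadable, and the whole picture is summed up by the limit of > 100000 nM in this assay, at which 3 of the 3 values shown sit.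

Compound 4 `C[Se]c1nc(NCc2ccccc2)c2ccccc2n1` differs from compound 3 by methyl in place of hydrogen on a selenium. Among the measured compounds shown here, the only measured step that alters the group on the selenium, a step that the two limits leave unreadable from compound 2 to compound 3, yields no size, so nothing measured speaks for a change in either direction. Compound 1, which bears the same methyl on selenium with a different benzylamine, sits at the same limit as everything else. Compound 4 is therefore expected to show no step beyond the scatter, with a step that the limit leaves unreadable from compound 3 to compound 4 as the estimated change from compound 3. The estimate for compound 4 in this assay is 200000 nM, within a range from 80000 nM to 1000000 nM, and most likely the measurement will again report only a limit.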

Compound 4, concentration lethal to 50% of the cells: 83500 nM
The estimate for compound 4 lay 2.4-fold (0.38 log units) above the measured number; the range from low to high includes it.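

With methyl in place of hydrogen on a selenium, compound 4 is the only compound shown that gives a number rather than a limit in this assay, which the earlier compounds could not show for this position: the limit of > 100000 nM in this assay, at which 3 of the 4 values shown sit. The change can now be given a size only as a floor, as an at least 1.1-fold lower number from compound 3 to compound 4 (0.07 log units; that floor lies within the scatter), and the same holds for a change at the end of the chain on the selenium, an at least 1.1-fold lower number from compound 2 to compound 4 (0.07 log units; that floor lies within the scatter), and for a change on the benzyl ring, an at least 1.1-fold lower number from compound 1 to compound 4 (0.07 log units; that floor lies within the scatter), so none of the three shows a difference beyond the scatter. Compound 1 carries the same methyl on the selenium and still reaches only a limit, which means that the methyl alone does not yield a measurable number and that the methoxy group has to be counted in the comparison.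

From the compounds shown here alone, how far compounds 1, 2 and 3 lie past their limits stays unknown, and with it the true size of all three steps. Also open, going by these compounds, is what an ethyl or propyl chain on the selenium would give, or a chain ending in an amine or a carboxylic acid.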